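A few compounds are considered here, and "the series" means these few. Any claim that something is new, unique, unknown or untested is made for them only; others in the source may bear on it.

Compound 2 `Cc1c(Nc2nc(N)c3c(C#N)c(N4CCC[C@H]4C)n(C)c3n2)cnn1C1COC1` gives 300 nM in an assay on HEK293 cells for inhibition of Leucine-rich repeat serine/threonine-protein kinase 2 (Homo sapiens), with a stated time of 48 h (on this read-out higher numbers stand for weaker inhibition and lower numbers for stronger inhibition), and stands at the lower of the two measured numbers, though the gap to compound 1 `Cc1c(Nc2nc(N)c3c(C#N)c(N4CCC[C@H]4C)n(C)c3n2)cnn1C` at 310 nM lies within the scatter. Compound 3 `Cc1nn(C)cc1Nc1nc(N)c2c(C#N)c(N3CCC[C@H]3C)n(C)c2n1` carries 1,3-dimethyl-1H-pyrazol-4-yl in place of 5-methyl-1-(oxetan-3-yl)-1H-pyrazol-4-yl on a nitrogen on an aromatic ring. Going by the values given here, the one measured step on this position, a 1.0-fold lower number from compound 1 to compound 2 (0.01 log units; within the scatter), changed nothing beyond the scatter, and the shifted methyl on the entering group has no measured counterpart. For compound 3 the expected step in this assay is a 1.2-fold higher number from compound 2 to compound 3 (0.07 log units; within the scatter), none beyond the scatter. Compound 3 is therefore estimated at 350 nM, within 150 nM to 800 nM.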

Compound 3, half-maximal inhibitory concentration: 190 nM
The estimate for compound 3 lay 1.8-fold (0.27 log units) above the measured number, and the stated range covers the measured number.
By their numbers in this assay, from the lowest: compounds 3, 2 and 1 (each within the scatter of the next).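

In this assay, the 1,3-dimethyl-1H-pyrazol-4-yl group on a nitrogen on an aromatic ring stays within the scatter of the group it replaces in both comparisons (a 1.6-fold lower number from compound 2 to compound 3 (0.20 log units; within the scatter)) and (a 1.6-fold lower number from compound 1 to compound 3 (0.21 log units; within the scatter)). The second comparison adds what the earlier pair could not show: exchanging the 1,5-dimethyl-1H-pyrazol-4-yl group for its 1,3-dimethyl counterpart also produces no step beyond the scatter. Nothing measured here accounts for these results.

Still open, going by these compounds, is whether a piperidin-4-yl group or a carboxylic acid on the pyrazole would give a step beyond the scatter.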